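A Hydroxy Acyl Swap From Compound 3

A few compounds are considered here, and "the series" means these few. Any claim that something is new, unique, unknown or untested is made for them only; others in the source may bear on it.

In a functional assay on U-87MG ATCC cells (Homo sapiens) for antiproliferative activity (on this read-out higher numbers stand for weaker inhibition and lower numbers for stronger inhibition), compound 1 `Cc1c2c(n3c1CCCN[C@@H](C)[C@H](C)Nc1cc-3ccc1C(N)=O)CC(C)(C)CC2=O` gives 61 nM and compound 2 `Cc1c2c(n3c1CCCN(C(=O)CO)[C@@H](C)[C@H](C)Nc1cc-3ccc1C(N)=O)CC(C)(C)CC2=O` gives 111 nM while compound 3 `COCCC(=O)N1CCc2c(C)c3c(n2-c2ccc(C(N)=O)c(c2)N[C@@H](C)[C@H](C)C1)CC(C)(C)CC3=O` gives 54 nM on the same read-out. Compound 3 thus lies within the scatter of compound 1 and beyond it against compound 2, whose number is higher. Compound 4 `Cc1c2c(n3c1CCN(C(=O)[C@@H](O)C(C)C)C[C@@H](C)[C@H](C)Nc1cc-3ccc1C(N)=O)CC(C)(C)CC2=O` carries 1-hydroxy-2-methylpropyl in place of 2-methoxyethyl on a carbonyl carbon in comparison with compound 3. Among the compounds with values here, the one step bearing on this is a 1.8-fold higher number from compound 1 to compound 2 (0.26 log units; within the scatter) with (hydroxymethyl)carbonyl in place of hydrogen on an amine nitrogen in a ring, and it stays within the scatter. No change beyond the scatter is therefore expected in this assay for this swap. The estimated step is a 1.4-fold higher number from compound 3 to compound 4 (0.14 log units; within the scatter) at the centre of that expectation. For compound 4 the estimated value is 75 nM with an expected range from 30 nM to 190 nM on this read-out.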

Compound 4, half-maximal inhibitory concentration: 76 nM
The estimate for compound 4 lay 1.0-fold (0.01 log units) below the measured number, and the stated range covers the measured number.
By their numbers in this assay, from the lowest: compounds 3, 1, 4 and 2 (each within the scatter of the next, the first and the last beyond it).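

Within this assay the change to 1-hydroxy-2-methylpropyl in place of 2-methoxyethyl on a carbonyl carbon gives a 1.4-fold higher number from compound 3 to compound 4 (0.15 log units; within the scatter) and stays within the scatter. The earlier step put an acyl group on the ring nitrogen, whereas this one shows that the group on that carbonyl can be exchanged, bringing in a hydrogen-bond donor and a defined stereocentre, without a change beyond the scatter. No measurement shown explains this result. The compounds shown leave open how the opposite configuration at that stereocentre would read. They also leave open whether an amine or a carboxylic acid on this carbonyl would stay within the scatter.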